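This account rests on a few compounds, and the source may have more. Where it says the series, first, only, none or still open, it means among the compounds named here.

Measured so far in an ADME assay (liver) for metabolic stability, with Liver microsome (Homo sapiens) as the target, read by LC-MS, using microsomes and NADPH, with a stated time of 5 min, at 37 degrees C; on this read-out higher numbers stand for fast clearance and lower numbers for slow clearance:
Compound 1 `CCn1c([C@@H](C)NS(=O)(=O)C2CC2)nc2ccc(C(F)(F)F)cc21` gives < 3 mL.min-1.g-1 as a limit of the assay, not a number.
Among the measured compounds shown here, compound 2 `CCn1c([C@@H](C)NS(=O)(=O)c2cn(C)nc2C)nc2ccc(C(F)(F)F)cc21` gives 28 mL.min-1.g-1 as the only full number.

Compound 2 is therefore the one firm starting point. Compound 3 `CCCn1cc(S(=O)(=O)N[C@H](C)c2nc3ccc(C(F)(F)F)cc3n2CC)c(C)n1` differs from compound 2 by ethyl in place of hydrogen on a saturated chain carbon bound to an aromatic nitrogen and so turns a methyl into a propyl. Going by the only measured step of an at least 9.3-fold higher number from compound 1 to compound 2 (0.97 log units; beyond the scatter) which brought in the 1,3-dimethyl-1H-pyrazol-4-yl group now being altered, a modest rise in this assay is expected, though that step is a different change and only a loose guide. The expected step is a 2.0-fold higher number from compound 2 to compound 3 (0.29 log units; within the scatter) in this estimate. For compound 3 the estimated value is 55 mL.min-1.g-1 with an expected range from 22 mL.min-1.g-1 to 130 mL.min-1.g-1 in this estimate.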

Compound 3, intrinsic clearance in microsomes: > 100 mL.min-1.g-1
Compound 3: a limit, no number; the forecaster's own chance of this, stated with the estimate: 1%; at least 1.8-fold (0.25 log units) between middle value and limit.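

In this assay, going from methyl to propyl gives an at least 3.5-fold higher number from compound 2 to compound 3 (0.55 log units; beyond the scatter), so this small change at the position counts for more than a step within the usual scatter would. Compound 3 reads as a limit of the assay, not a number: the limit of > 100 mL.min-1.g-1 in this assay, at which 1 of the 3 values shown sits. Across the change on the sulfonyl sulfur, the span is an at least 33-fold higher number from compound 1 to compound 3 (1.52 log units; beyond the scatter), which is the widest gap among the compounds shown.

As far as these compounds go, the true size of both steps stays open, since compound 3 has no full number. Also open, from the compounds shown here alone, is whether a methoxyethyl chain in place of propyl would read closer to compound 2 or compound 3.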